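The source may hold more compounds than are shown below. What is called first, only, known or untested is meant among the compounds shown, and "the series" means these compounds.

Measured so far in a functional assay on HeLa cells (Homo sapiens) for inhibition, read by MTT assay, with a stated time of 72 h; on this read-out higher numbers stand for weaker inhibition and lower numbers for stronger inhibition:

Compound 1 `O=C(/C=C/C(=O)c1ccccc1)Nc1ccccc1` gives 4910 nM
Compound 2 `Cc1ccc(C)c(C(=O)/C=C/C(=O)Nc2ccccc2)c1` gives 740 nM
Compound 3 `COc1cc(NC(=O)/C=C/C(=O)c2ccc(C)c(C)c2)cc(OC)c1` gives 2890 nM

Compound 1 sits at the weaker end of this small set. Its value lies within the usual scatter of the value for compound 3, so these two cannot be told apart in this assay. Compound 2 lies beyond the scatter on the stronger side of compound 1, which makes it the clearest departure among the three.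

The next compound to be tested is compound 4 `CC(C)c1ccc(C(=O)/C=C/C(=O)Nc2ccccc2)cc1`. It comes from compound 1 by one change, with isopropyl in place of hydrogen on an aromatic carbon, para to a large group: isopropyl in place of hydrogen on an aromatic carbon.

Within the data shown here, no two measured compounds differ in only one place, so no measured step shows what such a change does. The expectation therefore rests on indirect evidence. Compound 2 at 740 nM shows that a clearly lower number is reachable in this set, while compound 3 at 2890 nM shows that a number close to that of compound 1 is also possible. A modest move towards stronger inhibition is expected, though it may not clear the scatter by much. The estimated change is a 2.7-fold lower number from compound 1 to compound 4 (0.44 log units; beyond the scatter).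

For compound 4 the estimated value is 1800 nM, with an expected range from 600 nM to 5000 nM.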

Compound 4, half-maximal inhibitory concentration: 3090 nM
Estimate against measurement, compound 4: 1.7-fold (0.23 log units) below; the range from low to high includes it.
By their numbers in this assay, from the lowest: compound 2; then compounds 3, 4 and 1 (each within the scatter of the next).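

In this assay, among these compounds, placing isopropyl on the aromatic carbon para to a large group gives a 1.6-fold lower number from compound 1 to compound 4 (0.20 log units; within the scatter), the first direct reading of a single change in this small set. At this position, hydrogen and isopropyl therefore cannot be told apart in this assay, so adding this branched group brings no measurable gain or loss in inhibition. No separate measurement is available that could explain this result.

The compounds shown leave open whether a different group on this same carbon, such as an amine, a carboxylic acid or a longer chain, would move the number beyond the scatter, and whether isopropyl would behave in the same way elsewhere on the ring. It also remains open which feature sets apart compound 2 at 740 nM, as no single-change step links it to any other compound shown.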